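Swapping bromo for methyl on a whole-animal inhibition read-out

The compounds below may be only part of what the source reports. "The series", "measured", "known", "first", "only" and "open" are said of these compounds alone.

Of the compounds shown here, three have been tested in a functional assay on the whole organism for inhibition, with Mus musculus as the target, with a stated time of 2 h, at a dose of 50 mg/kg by the oral route; on this read-out higher numbers stand for more inhibition at the one dose given (going by the name of the read-out) and lower numbers for less inhibition. Compound 1, `Cc1ccc(-c2c(S(=O)(=O)c3ccccc3)cnc3ncnn23)cc1`, gives 5.2%. Compound 2, `O=S(=O)(c1ccccc1)c1cnc2ncnn2c1-c1ccc(Br)cc1`, gives 4.2%. Compound 3, `Cc1ccc(-c2c(S(=O)(=O)c3ccccc3)cnc3cc(-c4ccc(Br)cc4)nn23)cc1`, gives 72.6%, the highest of the three numbers and beyond the scatter of both others. The difference between the core of compound 2 and the core of compound 3 is not broken down here.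

Compound 1 and compound 2 differ in one place only, (methyl in place of bromo on an aromatic carbon), and the step in this assay is a number 1 percentage points higher from compound 2 to compound 1 (within the scatter), which lies within the scatter of repeated measurements, so these two values cannot be told apart.

Compound 4, `Cc1ccc(-c2cc3ncc(S(=O)(=O)c4ccccc4)c(-c4ccc(C)cc4)n3n2)cc1`, has not yet been measured. It differs from compound 3 by methyl in place of bromo on an aromatic carbon, the same change as that from compound 2 to compound 1, at the same kind of place on the same kind of ring.

The expected step in this assay is a number 2.6 percentage points lower from compound 3 to compound 4 (within the scatter), which rests on the earlier step of a number 1 percentage points higher from compound 2 to compound 1 (within the scatter) having stayed within the scatter. Among the measured compounds shown here, with only one measured example of this change, and at a high starting point where a fall is easier to see than a rise, the range is kept wide. Compound 4 is therefore expected to give about 70%. For compound 4 the likely span runs from 45% to 88%.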

Compound 4, a percentage reported as inhibition, in the whole organism at one dose (the size of the read-out at that dose, not a potency): 42.6%
For compound 4 the middle estimate is 27.4 percentage points above the measured one; measured number outside the range, below it.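

On the core of compound 3, putting methyl in place of bromo (4-bromophenyl to 4-methylphenyl) has a clear effect in this assay, with a number 30 percentage points lower from compound 3 to compound 4 (beyond the scatter) as the result. This change therefore cannot simply be carried from one core to another in this series, since the near-silent step on the smaller core did not predict the drop on the larger one: the same change on two cores in this assay, a number 1 percentage points higher (within the scatter) from compound 2 to compound 1 and a number 30 percentage points lower (beyond the scatter) from compound 3 to compound 4, 31 percentage points apart, beyond the scatter of two such steps. Among the compounds shown here, with only one pair on each core, this does not show which feature of the cores matters, how the change would behave on a third core, or how the compounds would compare at other doses, since the read-out gives the size of the inhibition at one dose and is not a potency.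

The compounds shown leave open whether another group at this same place on the ring, such as chloro, a methoxy group or an amine, would stay close to compound 3 or fall towards compound 4. For the compounds shown here, they also leave open what happens when bromo replaces methyl on the other 4-methylphenyl group, the one that compound 3 and compound 4 share.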